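Phenyl to pyridin-4-yl in compound 3

The source may hold more compounds than are shown below. What is called first, only, known or untested is meant among the compounds shown, and "the series" means these compounds.

Within the data shown here, only two compounds have numbers so far. In a functional assay on HT-29 cells (Homo sapiens) for cytotoxicity, read by MTT assay, with a stated time of 72 h (on this read-out lower numbers stand for stronger inhibition and higher numbers for weaker inhibition), compound 1 (`COc1ccc(NC(=O)CN2CCN(c3nnc(Cc4ccncc4)c4ccccc34)CC2)cc1OC`) gives 40100 nM and compound 2 (`Cc1ccccc1NC(=O)CN1CCN(c2nnc(Cc3ccccc3)c3ccccc23)CC1`) gives 113000 nM as the higher of the two numbers. The gap between them lies beyond the usual scatter, so compound 2 is the weaker of this pair.

Compound 3 (`Cc1ccccc1NC(=O)CN1CCN(c2nnc(Cc3ccncc3)c3ccccc23)CC1`) has not yet been measured. It departs from compound 2 by a single change, pyridin-4-yl in place of phenyl on a saturated chain carbon bound to an aromatic carbon which puts pyridin-4-yl in place of phenyl on a saturated chain carbon bound to an aromatic carbon.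

Among the measured compounds shown here, no measured pair isolates this change, so any expectation rests on thin evidence. For the measured compounds named here, the only guide is compound 1 at 40100 nM whose structure also shows the pyridin-4-yl group. A modest move to a lower number is therefore expected in this assay and the estimated step of a 2.3-fold lower number from compound 2 to compound 3 (0.35 log units; beyond the scatter) reflects that. For compound 3 the expected value is 50000 nM with an estimated range from 22000 nM to 115000 nM in repeat measurements.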

Compound 3, half-maximal inhibitory concentration: 15000 nM
Beside the measured number, compound 3's estimate is 3.3-fold (0.52 log units) above it; measured number outside the range, below it.
By their numbers in this assay, from the lowest: compound 3; then compound 1; then compound 2.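

In this assay, among these compounds, pyridin-4-yl in place of phenyl on a saturated chain carbon bound to an aromatic carbon now has a direct reading, with a 7.5-fold lower number from compound 2 to compound 3 (0.88 log units; beyond the scatter) as the first measured step in which nothing else differs. With pyridin-4-yl held constant, the group on the amide-type nitrogen also gets its first reading: 2-methylphenyl in place of 3,4-dimethoxyphenyl gives a 2.7-fold lower number from compound 1 to compound 3 (0.43 log units; beyond the scatter) and so also lies beyond the scatter, making both places in the molecule responsive in this assay, on one pair each. No supporting data at hand account for either step.

A single pair cannot show whether the gain from pyridin-4-yl carries over when 3,4-dimethoxyphenyl sits on the amide-type nitrogen, or whether it holds for other groups there. As far as these compounds go, it also remains open whether pyridin-3-yl or pyridin-2-yl at the same place would match the result of compound 3, or whether a pyrimidine ring or a longer chain to the ring would move the number further.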